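A Methyl-to-Chloro Swap on Compound 2

The source may hold more compounds than are shown below. What is called first, only, known or untested is meant among the compounds shown, and "the series" means these compounds.

In a functional assay on HeLa cells (Homo sapiens) for cytotoxicity, read by ELISA, with a stated time of 4 days (a lower number here means a stronger inhibitor, a higher number a weaker inhibitor), compound 1 (`Cc1ccsc1-c1cc(-c2ccoc2)cc(-c2ccc(Cl)cc2)n1`) gives 17400 nM. In the same test, compound 2 (`Cc1ccc(-c2cc(-c3ccoc3)cc(-c3ccc(Cl)s3)n2)cc1`) gives 28700 nM. These two numbers lie within the usual scatter of each other, so compound 2 stands level with compound 1 on the evidence so far, and both are measured only as a pair with different structures.

Compound 3 (`Clc1ccc(-c2cc(-c3ccoc3)cc(-c3ccc(Cl)s3)n2)cc1`) comes from compound 2 by one change: chloro in place of methyl on an aromatic carbon, turning 4-methylphenyl into 4-chlorophenyl. Among the measured compounds shown here, no measured pair shows this swap directly. Compound 1 also carries a 4-chlorophenyl group and gives 17400 nM, which offers only a loose guide. A small shift towards a lower number, not clearly beyond the scatter, is expected, estimated as a 1.4-fold lower number from compound 2 to compound 3 (0.14 log units; within the scatter). For compound 3 the estimated value is 21000 nM, with an expected range of 9000 nM to 48000 nM.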

Compound 3, half-maximal inhibitory concentration: 16500 nM
Compound 3: the middle estimate sits 1.3-fold (0.10 log units) above what was measured; the measured number falls inside the stated range.
By their numbers in this assay, from the lowest: compounds 3, 1 and 2 (each within the scatter of the next).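

In this assay the swap of 4-methylphenyl for 4-chlorophenyl now has a direct reading, a 1.7-fold lower number from compound 2 to compound 3 (0.24 log units; within the scatter), so at this place, para to a large group, chloro and methyl cannot be told apart by this test. A change in a different place, 5-chlorothiophen-2-yl in place of 3-methylthiophen-2-yl, gives a 1.1-fold lower number from compound 1 to compound 3 (0.02 log units; within the scatter), so that pair also stands level. Nothing measured here explains why these numbers stay so close.

Going by these compounds, what remains open is whether a quite different group at this para place, such as an amine or a carboxylic acid, would give a number beyond the scatter. On these data alone, with only these two steps, it also remains open whether any single change to this series can move the number clearly.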